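The source may hold more compounds than are shown below. What is called first, only, known or untested is meant among the compounds shown, and "the series" means these compounds.

Compounds measured so far:

Compound 1, `CNC1=C(Cl)C(=O)c2ncccc2C1=O`, 78900 nM
Compound 2, `O=C1C(NC(c2ccccc2)c2ccccc2)=C(Cl)C(=O)c2ncccc21`, 33900 nM

Of the compounds shown here, two have been tested in a functional assay on cells (Neutrophil, Homo sapiens) for inhibition, read by WST assay, with a stated time of 20 min; a lower number here means a stronger inhibitor, a higher number a weaker inhibitor. Compound 1 has the structure `CNC1=C(Cl)C(=O)c2ncccc2C1=O` and gives 78900 nM, the highest of the two numbers. Compound 2, with the structure `O=C1C(NC(c2ccccc2)c2ccccc2)=C(Cl)C(=O)c2ncccc21`, gives 33900 nM, a number lower than that of compound 1 by a margin that lies beyond the usual scatter. Within the data shown here, no pair of compounds differing in one place has been measured yet, so no single-change step is known from experiment.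

Compound 3, `CNC1=C(SC)C(=O)c2ncccc2C1=O`, is the next compound to be measured in this assay. It differs from compound 1 in one place: methylsulfanyl in place of chloro on a double-bonded ring carbon. Among the measured compounds shown here, there is no measured step of this kind to lean on. The expectation is a modest change, not clearly beyond the scatter, with at most a slight move toward a lower number, meaning a step of a 1.3-fold lower number from compound 1 to compound 3 (0.12 log units; within the scatter) from compound 1 to compound 3. Compound 3 is therefore expected to give about 60000 nM in this assay, with a likely range from 20000 nM to 200000 nM.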

Compound 3, half-maximal inhibitory concentration: > 200000 nM
Compound 3: a limit, no number (the forecaster's own chance of this, stated with the estimate: 15%); middle value at least 3.3-fold (0.52 log units) from the limit.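

In this assay, compound 3 gives > 200000 nM, which is a limit of the assay and not a number. On this double-bonded ring carbon, methylsulfanyl in place of chloro is not a neutral swap: it gives an at least 2.5-fold higher number from compound 1 to compound 3 (0.40 log units; beyond the scatter), a move toward weaker inhibition. Compound 1 and compound 2 both carry chloro on this carbon, so they could show nothing about it, whereas this change shows that the read-out responds to the group placed there, though the full size of the step stays unknown: the limit of > 200000 nM in this assay, at which 1 of the 3 values shown sits.

As far as these compounds go, with a single replacement at this carbon, it remains open whether the sulfur or its attached methyl matters, and whether a methoxy group, an amine or a bromine atom would keep the activity of the chloro compounds or lose it as well. From the compounds shown here alone, it is also open whether the same swap would act in the same direction on compound 2, which carries a much larger group on its nitrogen than the methylamino group of compound 1.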